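Methoxyphenyl for Bromophenyl on the Amide Carbonyl

The source may hold more compounds than are shown below. What is called first, only, known or untested is meant among the compounds shown, and "the series" means these compounds.

Measured so far in a functional assay on HeLa cells (Homo sapiens) for antiproliferative activity, read by CCK-8 assay, with a stated time of 72 h; on this read-out lower numbers stand for stronger inhibition and higher numbers for weaker inhibition:
compound 1, `O=C(Nc1cccc(-c2oc3cc(-c4ccc(F)cc4)ccc3c(=O)c2O)c1)c1ccccc1F`, gives 5630 nM;
compound 2, `Cc1ccc(C(=O)Nc2cccc(-c3oc4cc(-c5ccc(F)cc5)ccc4c(=O)c3O)c2)cc1`, gives 6190 nM;
compound 3, `O=C(Nc1cccc(-c2oc3cc(-c4ccc(F)cc4)ccc3c(=O)c2O)c1)c1ccc(Br)cc1`, gives 9740 nM.

Compound 3 is the compound from which the next step is taken. Its number is not separable from the other two: the steps of a 1.7-fold higher number from compound 1 to compound 3 (0.24 log units; within the scatter) and a 1.6-fold higher number from compound 2 to compound 3 (0.20 log units; within the scatter) both lie within the scatter, as does a 1.1-fold higher number from compound 1 to compound 2 (0.04 log units; within the scatter) between the other pair. On the numbers shown the three compounds behave alike.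

Compound 4, `COc1cccc(C(=O)Nc2cccc(-c3oc4cc(-c5ccc(F)cc5)ccc4c(=O)c3O)c2)c1`, differs from compound 3 in one place: 3-methoxyphenyl in place of 4-bromophenyl on a carbonyl carbon. Among the measured compounds shown here, no measured compound carries a methoxy group on this ring, so there is no step that bears on it directly. For the measured compounds named here, the steps that bear on it indirectly are the exchanges of the aryl group on the same carbonyl carbon, a 1.7-fold higher number from compound 1 to compound 3 (0.24 log units; within the scatter) and a 1.6-fold higher number from compound 2 to compound 3 (0.20 log units; within the scatter), both within the scatter. A change of the same kind is therefore expected to give no step beyond the scatter, the expected step being a 1.4-fold lower number from compound 3 to compound 4 (0.14 log units; within the scatter). Compound 4 is estimated at 7000 nM, with a range from 3500 nM to 14000 nM.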

Compound 4, half-maximal inhibitory concentration: 5650 nM
Compound 4: middle estimate off by 1.2-fold (0.09 log units), on the high side, and the stated range covers the measured number.
By their numbers in this assay, from the lowest: compounds 1, 4, 2 and 3 (each within the scatter of the next).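

In this assay the exchange on the carbonyl carbon gives a 1.7-fold lower number from compound 3 to compound 4 (0.24 log units; within the scatter), while the comparisons with the other two aryl groups give a 1.1-fold lower number from compound 2 to compound 4 (0.04 log units; within the scatter) and a 1.0-fold higher number from compound 1 to compound 4 (0.00 log units; within the scatter). The aryl group at this position can thus carry an oxygen-containing methoxy group, and the 3-methoxyphenyl group brings a hydrogen-bond acceptor that the 4-bromophenyl group lacks, yet all of these steps stay within the scatter. Nothing at hand accounts for this result or links it to any property of the group.

All four aryl amides remain indistinguishable here, so no substituent on this ring has yet been seen to move the number beyond the scatter. Going by these compounds, whether an amine or a carboxylic acid on the ring, or a longer chain in place of the ring, would do so remains open.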